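Chloro for fluoro on a weakly active amide series

The source may report more compounds than this note shows. Statements on the series, on what has been measured and on what is new or still open speak of the compounds shown alone.

Compound 1 `COc1ccc(-c2cc(C(=O)Nc3ccc(Oc4ccnc5[nH]ccc45)c(F)c3)ncn2)cc1` was examined in a functional assay on MCF7 cells (Homo sapiens) for cytotoxicity, read by MTT assay, with a stated time of 72 h (on this read-out lower numbers stand for stronger inhibition and higher numbers for weaker inhibition), and gave 10400 nM. Its companion compound 2 `O=C(Nc1ccc(Oc2ccnc3[nH]ccc23)c(F)c1)c1cc(-c2ccc(F)cc2)ncn1` carries a 4-fluorophenyl group in place of the methoxyphenyl group and was reported in this assay as "not active" (no number reported), so no single number describes where compound 2 stands; it can only be said that it showed no measurable inhibition under these conditions. Compound 3 `O=C(Nc1ccc(Oc2ccnc3[nH]ccc23)c(F)c1)c1cc(-c2ccc(Cl)cc2)ncn1` differs from compound 2 by chloro in place of fluoro on an aromatic carbon. Among the measured compounds shown here, no pair of measured compounds shows this step, so its size in this assay is unknown; the account expects a change of no more than the usual scatter, with no clear direction. On that basis compound 3 is estimated at 25000 nM, with a range from 6000 nM to 100000 nM, and a considerable chance that this assay again reports only inactivity.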

Compound 3, half-maximal inhibitory concentration: 26900 nM
Compound 3: middle estimate off by 1.1-fold (0.03 log units), on the low side; the range from low to high includes it.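

In this assay, this aromatic carbon now has a measured change in size: chloro in place of methoxy gives a 2.6-fold higher number from compound 1 to compound 3 (0.41 log units; beyond the scatter), so the methoxy group of compound 1 gives the lower number of the two. Compound 3 also shows that a halogen at this place can still return a number, although compound 2, with fluoro there, was reported only as not active, and the step from 4-fluorophenyl to 4-chlorophenyl cannot be read. Nothing available accounts for either observation.

From the compounds shown here alone, it remains open whether an amine, a nitrile or a longer alkoxy chain on this aromatic carbon would give a number lower than that of compound 1. Going by these compounds, it is also open whether any change at this place can move the series out of its weak range.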